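The source may hold more compounds than are shown below. What is called first, only, known or untested is meant among the compounds shown, and "the series" means these compounds.

Compound 1 `O=C(CCCc1ccccc1)Nc1nc2cc(Cl)ccc2c(=O)s1` gives > 1000 nM in an assay on CHO cells for displacement of a labelled ligand from adenosine receptor A2b (Homo sapiens), read by scintillation counting, with a stated time of 75 min (a lower number here means a stronger inhibitor, a higher number a weaker inhibitor), which is a limit of the assay and not a number.
Compound 2 `O=C(C/C=C/c1cccc(Cl)c1)Nc1nc2ccccc2c(=O)s1` gives > 1000 nM in this assay, again a limit of the assay rather than a number.
Compound 3 `O=C(CCc1ccccc1)Nc1nc2ccccc2c(=O)s1` gives 365 nM in this assay.

Compound 3 is therefore the only one of the three with a number in this assay; the other two sit at the limit of > 1000 nM in this assay, at which 2 of the 3 values shown sit, so nothing can be said of how far compound 3 stands from them beyond the fact that its value lies inside the measured range.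

Compound 4 `O=C(CCc1ccccc1F)Nc1nc2ccccc2c(=O)s1` differs from compound 3 in one place: fluoro in place of hydrogen on an aromatic carbon, on an aromatic carbon of a six-membered aromatic ring of carbon only. For the measured compounds named here, no measured pair shows this change here, so there is no step to lean on. The change is one atom on a ring that is otherwise kept, and in such cases the expected movement is small. Compound 4 is estimated at 300 nM in this assay, with a range of 100 nM to 1000 nM. The step this means, a 1.2-fold lower number from compound 3 to compound 4 (0.09 log units; within the scatter), is expected to lie within the usual scatter of the assay.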

Compound 4, inhibition constant: 801 nM
For compound 4 the middle estimate is 2.7-fold (0.43 log units) below the measured one; the measured number falls inside the stated range.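

For the compounds shown here, the change from phenyl to 2-fluorophenyl is the first step that can be read in this assay, and it amounts to a 2.2-fold higher number from compound 3 to compound 4 (0.34 log units; beyond the scatter) for a single added atom. This place on the ring, ortho to a large group, therefore does not take fluoro without a modest cost in the number, although compound 4 still gives a measured value. Compounds 1 and 2 remain at a limit, which is not a number, and so add nothing to this step: the limit of > 1000 nM in this assay, at which 2 of the 4 values shown sit.

The compounds shown leave open whether the rise belongs to fluoro itself or to this place on the ring, as one group at one place is all there is to go on. A chloro or methoxy group at the same place would help to separate the two.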